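Aryl swap on the pendant ring: compound 3 to compound 4

The source may hold more compounds than are shown below. What is called first, only, known or untested is meant among the compounds shown, and "the series" means these compounds.

Compound 1 `COc1cccc(-c2ccc3ncn(-c4cc(OC)c(OC)c(OC)c4)c3c2)c1` gives 3180 nM in a functional assay on A549 cells (Homo sapiens) for antiproliferative activity, read by MTT assay, with a stated time of 72 h; on this read-out lower numbers stand for stronger inhibition and higher numbers for weaker inhibition. Compound 2 `COc1cc(-n2cnc3ccc(-c4cccc([N+](=O)[O-])c4)cc32)cc(OC)c1OC` gives 5410 nM in this assay, and the step of a 1.7-fold higher number from compound 1 to compound 2 (0.23 log units; within the scatter) stays inside the scatter. Compound 3 `COc1cc(-n2cnc3ccc(-c4ccc(Cl)cc4Cl)cc32)cc(OC)c1OC` yields no number in this assay but only a limit, > 10000 nM. That is the limit of > 10000 nM in this assay, at which 1 of the 3 values shown sits, at which compound 3 stands. The steps of an at least 3.1-fold higher number from compound 1 to compound 3 (0.49 log units; beyond the scatter) and an at least 1.8-fold higher number from compound 2 to compound 3 (0.26 log units; that floor lies within the scatter) both run toward weaker inhibition on moving to the 2,4-dichlorophenyl ring, the first beyond the scatter, the second with a floor still inside it.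

Compound 4 `COc1cc(-n2cnc3ccc(-c4ccc(C)cc4F)cc32)cc(OC)c1OC` differs from compound 3 by 2-fluoro-4-methylphenyl in place of 2,4-dichlorophenyl on an aromatic carbon. Among the measured compounds shown here, no measured step compares these two aryl groups directly; the only bearing evidence is that both routes into compound 3 lost potency and ended at the limit. Compound 4 is therefore expected to remain weak, with an estimated step of an at least 1.1-fold lower number from compound 3 to compound 4 (0.04 log units; that floor lies within the scatter) of uncertain direction. Compound 4 is estimated at 9000 nM, within 2500 nM to 30000 nM, and a further limit is quite possible.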

Compound 4, half-maximal inhibitory concentration: > 10000 nM
Compound 4: a limit, no number; the forecaster's own chance of this, stated with the estimate: 45%; at least 1.1-fold (0.04 log units) between middle value and limit.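

In this assay compound 4, like compound 3, gives a limit and not a number, so the loss of a readable value at this position is not confined to the 2,4-dichlorophenyl ring or to its chlorine atoms: the limit of > 10000 nM in this assay, at which 2 of the 4 values shown sit. Set against the two rings that do give numbers, the change to 2-fluoro-4-methylphenyl gives an at least 3.1-fold higher number from compound 1 to compound 4 (0.49 log units; beyond the scatter) and an at least 1.8-fold higher number from compound 2 to compound 4 (0.26 log units; that floor lies within the scatter). The step between the two limits cannot be read, so the 2-fluoro-4-methylphenyl and 2,4-dichlorophenyl rings cannot be ranked, and among the four compounds only the 3-methoxyphenyl and 3-nitrophenyl rings give numbers.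

As far as these compounds go, how far compound 3 and compound 4 lie beyond their limits stays open. Also open, from the compounds shown here alone, is whether a pendant ring carrying an amine or a carboxylic acid would give a number at this position.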